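Removing the selenium side chain from compound 1

A few compounds are considered here, and "the series" means these few. Any claim that something is new, unique, unknown or untested is made for them only; others in the source may bear on it.

Going by the values given here, compound 1 `COc1ccc(N(C)c2nc(C)nc3ccccc23)cc1C(=O)OCCC[Se]C#N` holds the higher of the two numbers so far: in a functional assay on A549 cells (Homo sapiens) for inhibition, read by MTT assay, with a stated time of 48 h (on this read-out higher numbers stand for weaker inhibition and lower numbers for stronger inhibition), compound 1 gives 250 nM, while compound 2 `COc1ccc(N(C)c2nc(C)nc3ccccc23)cc1OCC[Se]C#N` gives 13 nM. Compound 3 `COc1ccc(N(C)c2nc(C)nc3ccccc23)cc1` has not yet been measured. It loses the whole side chain of compound 1: a hydrogen atom in place of a group of 9 heavy atoms (5 carbon, 1 nitrogen, 2 oxygen, 1 selenium; no ring), on an aromatic carbon. Among the compounds with values here, one measured step bears on this change. Placing a smaller selenium-bearing group on that aromatic carbon gave a 19-fold lower number from compound 1 to compound 2 (1.28 log units; beyond the scatter), a large step beyond the scatter. Within the data shown here, no measurement yet shows the effect of hydrogen there, so going that far is an extrapolation in the same direction. A large step of a 25-fold lower number from compound 1 to compound 3 (1.40 log units; beyond the scatter) is therefore expected, similar in size to the measured one. In this assay the expected value for compound 3 is 10 nM, with an estimated range of 2 nM to 50 nM.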

Compound 3, half-maximal inhibitory concentration: 3 nM
Estimate against measurement, compound 3: 3.3-fold (0.52 log units) above; the measured number falls inside the stated range.
By their numbers in this assay, from the lowest: compound 3; then compound 2; then compound 1.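

Replacing the side chain with hydrogen lowers the number in this assay further than either earlier compound suggested: the full change gives an 83-fold lower number from compound 1 to compound 3 (1.92 log units; beyond the scatter), and the shorter selenium-bearing chain also loses out, with a 4.3-fold lower number from compound 2 to compound 3 (0.64 log units; beyond the scatter). Among these three compounds, a low number at this aromatic carbon therefore does not depend on a selenium-bearing side chain, and the compound with hydrogen there gives the lowest number of all. No measurement offered here explains these differences.

The compounds shown leave open which part of each side chain goes with the higher numbers: the selenium atom, the nitrile or the chain itself. A plain ethoxy group or a hydroxyl group on this aromatic carbon would help to separate these parts.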